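The compounds below may be only part of what the source reports. "The series", "measured", "known", "first", "only" and "open" are said of these compounds alone.

Of the compounds shown here, three that share one core have been tested in a functional assay on NCI-H1975 cells (Homo sapiens) for inhibition, read by sulforhodamine B assay, tested at 10 uM; on this read-out higher numbers stand for more inhibition at the one concentration tested (going by the name of the read-out) and lower numbers for less inhibition. Compound 1 `CN1CCN(c2ccc(C3=NNC(c4ccc(N(C)C)cc4)C3)cc2)CC1` carries a hydrogen on an amine nitrogen in a ring, and in this assay compound 1 gives 2.4%. Compound 2 `COC(=O)CC(=O)N1N=C(c2ccc(N3CCN(C)CC3)cc2)CC1c1ccc(N(C)C)cc1` carries a ((methoxycarbonyl)methyl)carbonyl group on that nitrogen instead, and in this assay compound 2 gives -2.2%. Compound 3 `Cc1ccc(C(=O)N2N=C(c3ccc(N4CCN(C)CC4)cc3)CC2c2ccc(N(C)C)cc2)cc1` carries a (4-methylphenyl)carbonyl group there, and in this assay compound 3 gives -0.4%. Of the three numbers, that of compound 3 is the second highest, yet the gaps are small: the step of a number 2.8 percentage points lower from compound 1 to compound 3 (within the scatter) lay within the scatter, as did a number 4.6 percentage points lower from compound 1 to compound 2 (within the scatter) and a number 1.8 percentage points higher from compound 2 to compound 3 (within the scatter). Whatever group sits on that nitrogen, the three results cannot be told apart.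

Compound 4 `CN1CCN(c2ccc(C3=NN(C(=O)c4ccc(F)cc4)C(c4ccc(N(C)C)cc4)C3)cc2)CC1` differs from compound 3 in one place: fluoro in place of methyl on an aromatic carbon. Among the measured compounds shown here, no measured step touches a group on that six-membered aromatic ring. The nearest comparison is the exchange of the whole group on the carbonyl carbon, a number 1.8 percentage points higher from compound 2 to compound 3 (within the scatter), which stayed within the scatter. Every measured step in this assay has stayed within the scatter. Compound 4 is accordingly expected to show no step beyond it, a number 0.4 percentage points higher from compound 3 to compound 4 (within the scatter). Compound 4 is therefore estimated at 0% in this assay, with a range from -12% to 12%.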

Compound 4, a percentage reported as inhibition, at one concentration (the size of the read-out at that concentration, not a potency): 32.2%
Compound 4: middle estimate off by 32.2 percentage points, on the low side, and the stated range ends below it.
By their numbers in this assay, from the lowest: compounds 2, 3 and 1 (each within the scatter of the next); then compound 4.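

Exchanging one small group for another at this place, para to a large group on the six-membered aromatic ring, can change the read-out markedly: fluoro in place of methyl gives a number 32.6 percentage points higher from compound 3 to compound 4 (beyond the scatter), although each group counts one heavy atom and no hydrogen-bond donors or acceptors. The other two steps, a number 34.4 percentage points higher from compound 2 to compound 4 (beyond the scatter) and a number 29.8 percentage points higher from compound 1 to compound 4 (beyond the scatter), set the (4-fluorophenyl)carbonyl group apart from hydrogen and from the ((methoxycarbonyl)methyl)carbonyl group, so the earlier finding that the group on that nitrogen made no visible difference holds only among compounds 1, 2 and 3. Nothing available here bears on why this exchange has such an effect.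

From the compounds shown here alone, it remains open whether chloro, methoxy or a plain hydrogen at the same place would behave like fluoro or like methyl, and whether the gain belongs to fluoro specifically or to the loss of methyl. Going by these compounds, a reading at one concentration also gives the size of an effect and not a potency, so how potent compound 4 is stays unknown.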